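This account rests on a few compounds, and the source may have more. Where it says the series, first, only, none or still open, it means among the compounds named here.

Compound 2 `O=C1[C@@H](NS(=O)(=O)c2cc3ccc(Cl)nc3s2)CCN1Cc1cc2[nH]cccc-2n1`: 23%
Compound 1 `O=C1[C@@H](NS(=O)(=O)c2ccc(-c3ccccn3)s2)CCN1Cc1cc2[nH]cccc-2n1`: 8%

Within the data shown here, in an assay on isolated protein for inhibition of coagulation factor X (Oryctolagus cuniculus), tested at 1 uM (a lower number here means less inhibition, a higher number more inhibition at the concentration tested (going by the name of the read-out)), compound 2 gives 23%, the higher of the two numbers measured so far. In this assay compound 1 gives 8%, a gap beyond the usual scatter. Compound 3 `O=C1[C@@H](NS(=O)(=O)c2cc3ccc(Cl)nc3s2)CCN1Cc1cc2cc[nH]cc-2n1` has not yet been measured. It differs from compound 2 in one place: a group of 9 heavy atoms (7 carbon, 2 nitrogen; one five-membered aromatic ring with 1 hetero atom, one six-membered aromatic ring with 1 hetero atom) in place of a group of 9 heavy atoms (7 carbon, 2 nitrogen; one five-membered aromatic ring with 1 hetero atom, one six-membered aromatic ring with 1 hetero atom), on a saturated chain carbon bound to an amide-type nitrogen in a ring. Among the measured compounds shown here, no measured pair shows the effect of such a rearrangement, so the size of the step is unknown. The step is expected to be small, a number 5 percentage points lower from compound 2 to compound 3 (within the scatter), probably within the scatter. Compound 3 is expected to give 18%, in a range from 3% to 40%.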

Compound 3, a percentage reported as inhibition, at one concentration (the size of the read-out at that concentration, not a potency): 50%
Compound 3: middle estimate off by 32 percentage points, on the low side; measured number outside the range, above it.
By their numbers in this assay, from the lowest: compound 1; then compound 2; then compound 3.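

Rearranging the same atoms in the group on a saturated chain carbon bound to an amide-type nitrogen in a ring gives, in this assay, a number 27 percentage points higher from compound 2 to compound 3 (beyond the scatter), with the other parts of the molecule unchanged. This position therefore responds to how the group's atoms are joined, even though the counts of atoms, hydrogen-bond donors and acceptors stay the same. No measurement here explains the difference. On these data alone, it remains open whether the same rearrangement would act alike on the core of compound 1. As far as these compounds go, how an amine or a methoxy group on this group would read out also remains open.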